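A few compounds are considered here, and "the series" means these few. Any claim that something is new, unique, unknown or untested is made for them only; others in the source may bear on it.

Measured in a physicochemical assay for pharmacokinetics; a lower number here means that the compound disappears faster, a higher number that the compound lasts longer:
Compound 1 `O=C(NCc1ccccc1)N1C(=O)c2ccccc2S1(=O)=O`: > 166 h
Compound 2 `Cc1ccccc1CNC(=O)N1C(=O)c2ccccc2S1(=O)=O`: > 166 h

Compound 2 has no exact value, only a limit of the assay at > 166 h. Compound 1 also reached only a limit, at > 166 h. The next compound, compound 3 `COc1ccccc1CNC(=O)N1C(=O)c2ccccc2S1(=O)=O`, differs from compound 2 by methoxy in place of methyl on an aromatic carbon, ortho to a large group: methoxy in place of methyl on an aromatic carbon. Going by the values given here, the one measured step that bears on this change is a step that the two limits leave unreadable from compound 1 to compound 2, and it offers no size to carry over. The evidence so far is the limit of > 166 h in this assay, at which 2 of the 2 values shown sit, so a step beyond the scatter is not expected, and another limit is the likeliest result. The expected change is a step that the limit leaves unreadable from compound 2 to compound 3, which is estimated to lie within the scatter. For compound 3 the estimated half-life is 200 h, with an expected range of 110 h to 350 h.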

Compound 3, half-life: > 166 h
Compound 3 was reported as a limit (the forecaster's own chance of this, stated with the estimate: 80%); the middle value is on the limit's open side.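

In this assay compound 3 gives > 166 h, which is a limit of the assay. The steps among compound 1, compound 2 and compound 3 cannot be read. The compounds shown leave open what the half-life of each one is, and whether methyl or methoxy in place of hydrogen changes it at all.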